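Methyl in Place of Cyano on the Phenyl Ring

This account rests on a few compounds, and the source may have more. Where it says the series, first, only, none or still open, it means among the compounds named here.

Three analogues sharing one core have been measured in a functional assay on PANC-1 cells (Homo sapiens) for inhibition, read by MTT assay, with a stated time of 24 h; on this read-out lower numbers stand for stronger inhibition and higher numbers for weaker inhibition. Compound 1 `CC1(C)[C@H]2CC[C@]1(C)N(Cc1cn(-c3cccc(Cl)c3)nn1)C(=O)C2` gives 260 nM, compound 2 `CC1(C)[C@H]2CC[C@]1(C)N(Cc1cn(-c3ccccc3)nn1)C(=O)C2` gives 160 nM, and compound 3 `CC1(C)[C@H]2CC[C@]1(C)N(Cc1cn(-c3cccc(C#N)c3)nn1)C(=O)C2` gives 260 nM. Compound 3 stands level with compound 1, the two together giving the highest numbers of the three, and no change at the digits printed from compound 1 to compound 3 (within the scatter); compound 2 is the furthest from compound 3. Compound 4 `Cc1cccc(-n2cc(CN3C(=O)C[C@@H]4CC[C@@]3(C)C4(C)C)nn2)c1` differs from compound 3 by methyl in place of cyano on an aromatic carbon. Among the measured compounds shown here, two measured steps concern the same aromatic carbon: no change at the digits printed from compound 1 to compound 3 (within the scatter) and a 1.6-fold higher number from compound 2 to compound 3 (0.21 log units; within the scatter). Both lie within the scatter, so swapping the group at this place has not yet moved this assay beyond it, and no step beyond the scatter is expected for a 1.2-fold lower number from compound 3 to compound 4 (0.07 log units; within the scatter). Compound 4 is therefore estimated at 220 nM, with a range from 110 nM to 440 nM.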

Compound 4, half-maximal inhibitory concentration: 240 nM
The estimate for compound 4 lay 1.1-fold (0.04 log units) below the measured number; the measured number falls inside the stated range.
By their numbers in this assay, from the lowest: compounds 2, 4, 1 and 3 (each within the scatter of the next).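

In this assay, methyl at this aromatic carbon gives a 1.1-fold lower number from compound 3 to compound 4 (0.03 log units; within the scatter) and a 1.1-fold lower number from compound 1 to compound 4 (0.03 log units; within the scatter) and a 1.5-fold higher number from compound 2 to compound 4 (0.18 log units; within the scatter), all three steps lying within the scatter. Hydrogen, chloro, cyano and now methyl therefore all give numbers within the scatter of one another at this place. Exchanging cyano, with its hydrogen-bond acceptor, for methyl, with none, also leaves the number within the scatter. As far as these compounds go, whether an amine, a carboxylic acid or a longer chain here would move the number beyond the scatter remains open. No measurement at hand bears on why these four numbers lie so close together.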